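This account rests on a few compounds, and the source may have more. Where it says the series, first, only, none or still open, it means among the compounds named here.

Compound 3 `CN(c1nc2ccc(NC(=O)CCc3ccc(C(F)(F)F)cc3)cc2[nH]1)C1CCOC1` is measured in an assay on CHO-K1 cells for displacement of a labelled ligand from melanin-concentrating hormone receptor 1 (Homo sapiens), read by scintillation counting (a lower number here means a stronger inhibitor, a higher number a weaker inhibitor), at 27 nM. Compound 1 `CC(C)N(C)c1nc2ccc(NC(=O)c3cnc(-c4ccc(F)cc4)cn3)cc2[nH]1` gives 2.7 nM in this assay, a gap to compound 3 that lies beyond the scatter. Compound 2 `CC(C)N(C)c1ccc2cc(NC(=O)CCc3ccc(C(F)(F)F)cc3)cnc2n1`, built on a different core, gives 365 nM, again beyond the scatter from compound 3. Compound 3 thus stands between the other two, nearer to compound 1. Compound 4 `CN(c1nc2ccc(NC(=O)CCc3ccc(C(F)(F)F)cc3)cc2[nH]1)C1CCCCC1` differs from compound 3 only as cyclohexyl in place of oxolan-3-yl on a nitrogen on an aromatic ring. Among the measured compounds shown here, no measured pair in the set carries this same change, so nothing directly shows its size. The step expected from compound 3 to compound 4 is a 1.5-fold lower number from compound 3 to compound 4 (0.18 log units; within the scatter), either none beyond the scatter or a small move toward a lower number. Compound 4 is estimated in this assay at 18 nM, with a range from 6 nM to 60 nM.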

Compound 4, half-maximal inhibitory concentration: 6.7 nM
For compound 4 the middle estimate is 2.7-fold (0.43 log units) above the measured one, and the stated range covers the measured number.
By their numbers in this assay, from the lowest: compound 1; then compound 4; then compound 3; then compound 2.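

Cyclohexyl in place of oxolan-3-yl on this nitrogen gives a 4.0-fold lower number from compound 3 to compound 4 (0.61 log units; beyond the scatter) in this assay, the first single-place step in the series. The group on this nitrogen therefore moves the read-out, and the ring oxygen of oxolan-3-yl is not needed for the lower number in this pair. Nothing at hand gives a cause for the step. Ring size and loss of the oxygen change together here, so a cyclopentyl or oxan-4-yl group would be needed to separate them. Going by these compounds, whether the step carries over to the cores of compound 1 or compound 2 also remains open.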